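A few compounds are considered here, and "the series" means these few. Any claim that something is new, unique, unknown or untested is made for them only; others in the source may bear on it.

Compound 2 `O=C(/C=C/c1cccc(NC(=S)Nc2ccccc2)c1)C[C@@H]1OC[C@@H](O)[C@H](O)[C@H]1O` is one of three compounds tested in an ADME assay on Vero cells (Chlorocebus sabaeus) for cytotoxicity, read by resazurin assay, with a stated time of 2 days; a lower number here means that less compound is tolerated, a higher number that more compound is tolerated. Compound 1 `CCOC(=O)/C=C/c1cccc(NC(=S)Nc2ccccc2)c1` gives 279000 nM in this assay, compound 2 gives 289000 nM, and compound 3 `CC(=O)OC[C@H]1O[C@@H](CC(=O)/C=C/c2ccc(NC(=O)Nc3ccc4ccccc4c3)cc2)[C@H](OC(C)=O)[C@@H](OC(C)=O)[C@@H]1OC(C)=O` gives 482000 nM. Compound 2 stands second highest of the three numbers, closest to compound 1 and furthest from compound 3, with both gaps within the scatter. Going by the values given here, the one step from measured compounds that differ in a single place is a 1.0-fold higher number from compound 1 to compound 2 (0.02 log units; within the scatter), a change on the carbonyl carbon that left the number essentially unchanged.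

Compound 4 `Cc1ccc(S(=O)(=O)Nc2cccc(/C=C/C(=O)C[C@@H]3OC[C@@H](O)[C@H](O)[C@H]3O)c2)cc1` differs from compound 2 at another place: a group of 10 heavy atoms (7 carbon, 2 oxygen, 1 sulfur; one six-membered aromatic ring of carbon only) in place of a group of 9 heavy atoms (7 carbon, 1 nitrogen, 1 sulfur; one six-membered aromatic ring of carbon only), on a nitrogen on an aromatic ring. Among the compounds with values here, no measured step touches this nitrogen, so the only guide is that all three numbers in this assay sit close together regardless of the change made. Compound 4 is therefore expected to show a step of a 1.0-fold higher number from compound 2 to compound 4 (0.00 log units; within the scatter), that is, no change beyond the scatter. Compound 4 is estimated at 290000 nM, with a likely range from 150000 nM to 560000 nM.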

Compound 4, half-maximal cytotoxic concentration: 94700 nM
For compound 4 the middle estimate is 3.1-fold (0.49 log units) above the measured one; the whole stated range lies above it.
By their numbers in this assay, from the lowest: compound 4; then compounds 1, 2 and 3 (each within the scatter of the next).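

In this assay, the group on the nitrogen on an aromatic ring proves to matter: (4-methylphenyl)sulfonyl in place of the group of 9 heavy atoms gives a 3.1-fold lower number from compound 2 to compound 4 (0.48 log units; beyond the scatter). The earlier change on the carbonyl carbon, a 1.0-fold higher number from compound 1 to compound 2 (0.02 log units; within the scatter), lay within the scatter, so this nitrogen is the only place shown where a change moves the number beyond it, and the move is towards less compound being tolerated. Nothing available explains this step.

Going by these compounds, whether the sulfonyl link or the 4-methylphenyl ring accounts for the step stays open, as does whether a methylsulfonyl group, an acetyl group or the free amine on this nitrogen would give a number nearer to that of compound 2 or compound 4. On these data alone, it is also open whether the same exchange would give a similar step with ethoxy on the carbonyl carbon.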